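The source may report more compounds than this note shows. Statements on the series, on what has been measured and on what is new or still open speak of the compounds shown alone.

Measured in a functional assay on HCT-116 cells (Homo sapiens) for antiproliferative activity, read by MTT assay, with a stated time of 48 h; a higher number here means a weaker inhibitor, a lower number a stronger inhibitor:
- Compound 1 `CCCCCC(CCO)n1cnc2c(Cl)nc(F)nc21`: 8660 nM
- Compound 2 `CCCCCC(CCO)n1cnc2c(Cl)ncnc21`: > 50000 nM (a limit, not a number)
- Compound 3 `C=C(CO)C(CCCCC)n1cnc2c(Cl)ncnc21`: > 50000 nM (a limit, not a number)

Compound 2 has no exact value and stands at the limit of > 50000 nM in this assay, at which 2 of the 3 values shown sit. Compound 4 `CCCCCCCCCCC(CCO)n1cnc2c(Cl)ncnc21` differs from compound 2 by pentyl in place of hydrogen on a saturated chain carbon, six bonds along the chain from an aromatic nitrogen. The same difference, cut one bond further out, reads methyl to hexyl.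

Two measured steps start or end at compound 2, and neither tests this change. The first is an at least 5.7-fold higher number from compound 1 to compound 2 (0.76 log units; beyond the scatter), which is hydrogen in place of fluoro on an aromatic carbon and leaves the chain untouched. The second is a step that the two limits leave unreadable from compound 2 to compound 3, so it offers no size to borrow. The data therefore hold no direct measure of what the pentyl will do.

Compound 1 does show that a compound of this family can give a real number, 8660 nM. On that basis, and given how large the structural change is, a modest move towards a lower number is expected, although a result at the limit would be no surprise. The expected change is an at least 2.5-fold lower number from compound 2 to compound 4 (0.39 log units; beyond the scatter). In this assay, compound 4 is estimated at 20000 nM, with an expected range of 6000 nM to 50000 nM.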

Compound 4, half-maximal inhibitory concentration: 4930 nM
Compound 4: the middle estimate sits 4.1-fold (0.61 log units) above what was measured; the whole stated range lies above it.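

Adding pentyl in place of hydrogen on a saturated chain carbon, six bonds along the chain from an aromatic nitrogen, gives an at least 10-fold lower number from compound 2 to compound 4 (1.00 log units; beyond the scatter) in this assay. Within the data shown here, until this result, the only readable step lay on an aromatic carbon, and the other step among the earlier compounds could not be read, so this is the first sign that a change on the chain alone can move the number beyond the scatter. The true size of the step remains open at one end, because compound 2 has a limit and not an exact number: the limit of > 50000 nM in this assay, at which 2 of the 4 values shown sit.

The compounds shown do not tell whether a shorter chain such as propyl, or a longer chain such as octyl, would lower the number further, or whether a pentyl chain carrying an amine or a carboxylic acid would keep the effect. They also leave open whether fluoro on the aromatic carbon and pentyl on the chain would add together in a single compound.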